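This account rests on a few compounds, and the source may have more. Where it says the series, first, only, none or still open, it means among the compounds named here.

In a functional assay on the whole organism (strain Swiss CD-1) with Mus musculus as the target, with a stated time of 2 h (on this read-out higher numbers stand for an effect only at larger amounts of compound and lower numbers for an effect already at smaller amounts), compound 1 (`COCC(C(=O)N1CCN(c2ccc(Cl)cc2)CC1)N1C(=O)CCC1=O`) gives 45.5 mg/kg and compound 2 (`COC[C@@H](C(=O)N1CCN(c2ccc(C(F)(F)F)cc2)CC1)N1C(=O)CCC1=O`) gives 37.9 mg/kg. These two values lie within the usual scatter of each other, so the numbers do not separate compound 2 from compound 1. Going by the values given here, the two compounds differ in more than one place, and no single-place step between measured compounds is available.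

Compound 3 (`COCC(C(=O)N1CCN(c2ccc(C(F)(F)F)cc2)CC1)N1C(=O)CCC1=O`) has no value yet. Its difference from compound 2 is confined to how one stereocentre is drawn: the two compounds have the same atoms and bonds; at least one stereo element is drawn with a configuration in one of them and without one in the other: 1 of 1 stereo elements differ; a stereocentre at a saturated chain carbon is drawn S in compound 2 and without a configuration in compound 3. Among the compounds with values here, no measured pair isolates a change of this kind, so the expectation rests on two values only. Compound 2 gives 37.9 mg/kg, and compound 1, also drawn without a configuration at its stereocentre, gives 45.5 mg/kg.

The expected size of a 1.2-fold higher number from compound 2 to compound 3 (0.07 log units; within the scatter) is nothing beyond the scatter, with any drift expected toward a higher number. In this assay, compound 3 is estimated at 45 mg/kg, with an expected range from 28 mg/kg to 80 mg/kg.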

Compound 3, dose for half-maximal effect: 22.4 mg/kg
Compound 3: middle estimate off by 2.0-fold (0.30 log units), on the high side; the whole stated range lies above it.
By their numbers in this assay, from the lowest: compounds 3, 2 and 1 (each within the scatter of the next, the first and the last beyond it).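

In this assay, a 1.7-fold lower number from compound 2 to compound 3 (0.23 log units; within the scatter), so drawing the saturated chain carbon as S or leaving it without a configuration does not separate these two compounds by their numbers. The only difference available for reading this pair is a matter of depiction, and the numbers give no sign that a defined configuration at this position matters: the fact that one of compounds 2 and 3 is drawn with a defined configuration and the other without, at the place where they differ

The aromatic position now has its first single-place step, with both compounds drawn without a configuration: a 2.0-fold lower number from compound 1 to compound 3 (0.31 log units; beyond the scatter). This trifluoromethyl-for-chloro change is modest, and it rests on one pair in one assay, so it is a single observation and not a trend.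

Open, going by these compounds, is what the R configuration at the stereocentre would give, and whether compound 3 holds both configurations, which its drawing does not state. Also open, on these data alone, is how the aromatic position responds to a group such as nitrile, or to a hydrogen there, and whether an ethoxy in place of the methoxy on the chain shifts the dose for half-maximal effect.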